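Triazine sulfonamide hydrazones: aryl swap on the imine carbon

This account rests on a few compounds, and the source may have more. Where it says the series, first, only, none or still open, it means among the compounds named here.

Measured so far:
compound 1, `NS(=O)(=O)c1ccc(Nc2nc(N/N=C/c3ccc(C(F)(F)F)cc3)nc(Nc3ccccc3)n2)cc1`, in a functional assay on MDA-MB-231 cells (Homo sapiens) for inhibition, read by sulforhodamine B assay, with a stated time of 48 h (a lower number here means a stronger inhibitor of growth, a higher number a weaker inhibitor of growth), compound 1 gives 2310 nM
compound 2, `Cc1nn(-c2ccccc2)cc1/C=N/Nc1nc(Nc2ccccc2)nc(Nc2ccc(S(N)(=O)=O)cc2)n1`, in this assay compound 2 gives 3110 nM

Within the data shown here, compound 2 holds the higher of the two numbers so far, its nearest neighbour being compound 1; the gap a 1.3-fold higher number from compound 1 to compound 2 (0.13 log units; within the scatter) is within the scatter, so the two are not told apart.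

Compound 3, `NS(=O)(=O)c1ccc(Nc2nc(N/N=C/c3ccccn3)nc(Nc3ccccc3)n2)cc1`, is not yet measured. It differs from compound 2 by pyridin-2-yl in place of 3-methyl-1-phenyl-1H-pyrazol-4-yl on a carbon with a double bond to nitrogen. Among the measured compounds shown here, the only measured step that touches this position is the swap of the aryl group on the same imine carbon, a 1.3-fold higher number from compound 1 to compound 2 (0.13 log units; within the scatter), which moved the number by less than the scatter. On that basis no step beyond the scatter is expected in this assay for a further exchange at the same place, in either direction.

Compound 3 is therefore estimated at 2600 nM, with a range of 1000 nM to 7000 nM, meaning an expected step of a 1.2-fold lower number from compound 2 to compound 3 (0.08 log units; within the scatter).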

Compound 3, concentration for 50% growth inhibition: 500 nM
Estimate against measurement, compound 3: 5.2-fold (0.72 log units) above, outside the stated range (below it).
By their numbers in this assay, from the lowest: compound 3; then compounds 1 and 2 (each within the scatter of the next).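

The position on the imine carbon is not indifferent to the aryl group: in this assay pyridin-2-yl gives a 6.2-fold lower number from compound 2 to compound 3 (0.79 log units; beyond the scatter) and also a 4.6-fold lower number from compound 1 to compound 3 (0.66 log units; beyond the scatter), both beyond the scatter. The swap between the two earlier groups gave no such separation, so the result sets pyridin-2-yl apart from both 3-methyl-1-phenyl-1H-pyrazol-4-yl and 4-(trifluoromethyl)phenyl in this series. No measurement available here accounts for these steps.

The compounds shown leave open whether the steps depend on the ring nitrogen of pyridin-2-yl or on the removal of the substituents carried by the other two groups. An unsubstituted phenyl group and a pyridin-4-yl group on the same carbon would help separate these two readings.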